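Trimming a benzyl to a methyl on the tetrazole

The source may hold more compounds than are shown below. What is called first, only, known or untested is meant among the compounds shown, and "the series" means these compounds.

Measured so far:
Compound 1, `CC(C)(N)CC(=O)N[C@@H]1CCc2ccccc2N(Cc2ccc(-c3ccccc3-c3nnn(Cc4ccccc4)n3)cc2)C1=O`: 1 uM
Compound 2, `CC(C)(N)CC(=O)N[C@@H]1CCc2ccccc2N(Cc2ccc(-c3ccccc3S(=O)(=O)NC(C)(C)C)cc2)C1=O`: 4 uM

In a functional assay (Pituitary gland cell) with Rattus norvegicus as the target (on this read-out higher numbers stand for an effect only at larger amounts of compound and lower numbers for an effect already at smaller amounts), compound 1 gives 1 uM, the lowest of the two numbers. Going by the values given here, its only measured neighbour is compound 2, which in this assay gives 4 uM; the step of a 4.0-fold higher number from compound 1 to compound 2 (0.60 log units; beyond the scatter) is modest and arises from (tert-butyl)sulfamoyl in place of 2-benzyl-2H-tetrazol-5-yl on an aromatic carbon.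

Compound 3, `Cn1nnc(-c2ccccc2-c2ccc(CN3C(=O)[C@H](NC(=O)CC(C)(C)N)CCc4ccccc43)cc2)n1`, has not yet been measured. Its difference from compound 1 is hydrogen in place of phenyl on a saturated chain carbon bound to an aromatic nitrogen. Among the compounds with values here, no measured step covers this change. The step from compound 1 to compound 2 alters the same part of the molecule, but it exchanges the whole tetrazole for a different group, so it shows only that rebuilding this region of compound 1 costs a modest amount in this assay; it does not say what keeping the tetrazole and shortening its substituent will do. With no direct guide, a small step, if any, is expected, with weakening somewhat more likely than gain. Compound 3 is estimated to give 2 uM in this assay, within 0.5 uM to 8 uM, which is expected to mean a 2.0-fold higher number from compound 1 to compound 3 (0.30 log units; within the scatter).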

Compound 3, concentration for half-maximal effect: 0.3 uM
Compound 3: the middle estimate sits 6.7-fold (0.82 log units) above what was measured; the measured number lies below the stated range.
By their numbers in this assay, from the lowest: compound 3; then compound 1; then compound 2.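

In this assay the phenyl of the benzyl on the tetrazole proves dispensable: cutting benzyl to methyl gives a 3.3-fold lower number from compound 1 to compound 3 (0.52 log units; beyond the scatter) and so moves the number down, not up. The earlier pair showed only that exchanging the whole 2-benzyl-2H-tetrazol-5-yl for (tert-butyl)sulfamoyl cost a modest step, whereas with 2-methyl-2H-tetrazol-5-yl the comparison with the same sulfamoyl group becomes a 13-fold lower number from compound 2 to compound 3 (1.12 log units; beyond the scatter) and is large, so the size of the gap between tetrazole and sulfamoyl depends on what the tetrazole carries. Nothing in the information at hand accounts for the lower number with the smaller substituent.

With only benzyl and methyl on the tetrazole, the compounds shown leave open how the number behaves with an ethyl or a longer chain there, or with a bare hydrogen on that tetrazole nitrogen. They also leave open whether the tetrazole itself could give way to a carboxylic acid on the same aromatic carbon while the methyl compound's low number is kept.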